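The source may hold more compounds than are shown below. What is called first, only, known or untested is meant among the compounds shown, and "the series" means these compounds.

In a functional assay on A549 cells (Homo sapiens) for antiproliferative activity, read by MTT assay, with a stated time of 48 h (a higher number here means a weaker inhibitor, a lower number a stronger inhibitor), compound 1 (`COc1cccc(N2CCN(C(=O)/C=C/c3ccc(O)c(O)c3)CC2)c1`) gives 1.27 ug/mL in the series, compound 2 (`O=C(/C=C/c1ccc(O)c(O)c1)N1CCN(c2cccc(C(F)(F)F)c2)CC1`) gives 1.74 ug/mL and compound 3 (`Cc1ccc(N2CCN(C(=O)/C=C/c3ccc(O)c(O)c3)CC2)c(C)c1`) gives 1.02 ug/mL in the same read-out. Compound 1 lies within the scatter of both other compounds, so its place among the three numbers sets no ranking.

Compound 4 (`CCN1CCN(C(=O)/C=C/c2ccc(O)c(O)c2)CC1`) carries ethyl in place of 3-methoxyphenyl on an amine nitrogen in a ring, and the counted difference is ethyl in place of 3-methoxyphenyl on an amine nitrogen in a ring in full.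

Among the measured compounds shown here, two measured steps bear on this change. The first is a 1.4-fold higher number from compound 1 to compound 2 (0.14 log units; within the scatter) for trifluoromethyl in place of methoxy on an aromatic carbon. The second is a 1.2-fold lower number from compound 1 to compound 3 (0.10 log units; within the scatter) for 2,4-dimethylphenyl in place of 3-methoxyphenyl on the same nitrogen. Both are small, but both keep an aromatic ring at that place, whereas compound 4 has no ring there. For the measured compounds named here, no measured compound carries ethyl at that nitrogen, so these steps are only a weak guide.

A step somewhat larger than either measured one is tentatively expected in this assay, towards a higher number, and it may not clear the scatter. The estimated change is a 2.0-fold higher number from compound 1 to compound 4 (0.29 log units; within the scatter) on this reasoning. The estimate for compound 4 is 2.5 ug/mL as a central value, with an expected range from 0.9 ug/mL to 7 ug/mL on repeat measurement.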

Compound 4, half-maximal inhibitory concentration: 6.54 ug/mL
For compound 4 the middle estimate is 2.6-fold (0.42 log units) below the measured one; measured number inside the range.
By their numbers in this assay, from the lowest: compounds 3, 1 and 2 (each within the scatter of the next); then compound 4.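

In this assay, the steps among compounds that keep an aromatic ring on the amine nitrogen stayed within the scatter, but ethyl at this place gives a 5.1-fold higher number from compound 1 to compound 4 (0.71 log units; beyond the scatter) and a 6.4-fold higher number from compound 3 to compound 4 (0.81 log units; beyond the scatter). Among the compounds shown here, this is the first change to clear the scatter: 3-methoxyphenyl and 2,4-dimethylphenyl cannot be told apart here, while ethyl, which has no ring, stands clearly apart from both, a finding that rests on these two pairs alone. No measured data shown here explain this difference.

For the compounds shown here, the single ethyl compound cannot separate loss of the aromatic ring from loss of group size, and cyclohexyl or a longer chain such as hexyl on the same nitrogen would address that question. Going by these compounds, it also remains open whether benzyl, which keeps an aromatic ring but adds a carbon link to the nitrogen, or pyridyl, which puts nitrogen into the aromatic ring, would stay within the scatter of compound 1.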